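Mirror image of compound 1: inverting both stereocentres

The source may report more compounds than this note shows. Statements on the series, on what has been measured and on what is new or still open speak of the compounds shown alone.

Measured so far in an in vitro assay on HEK-293T cells for displacement of a labelled ligand from Neuronal acetylcholine receptor; alpha3/alpha6/beta2/beta3 (Homo sapiens); on this read-out lower numbers stand for stronger inhibition and higher numbers for weaker inhibition:
compound 1 `CN1C[C@H]2C=C(c3cccnc3)C[C@H](C2)C1` gives 300 nM
compound 2 `C1=C(c2cccnc2)C[C@H]2CNC[C@@H]1C2` gives 0.95 nM
compound 3 `C1=C(c2cncc(Oc3ccccc3)c2)CC2CNCC1C2` gives 4.8 nM

Compound 1 stands at the weakest end of the three numbers in this assay. Its nearest neighbour is compound 3, which carries a phenoxy-substituted pyridine on an unsubstituted core; the gap between their values is beyond the scatter. The furthest is compound 2, reached by one change: a 320-fold lower number from compound 1 to compound 2 (2.50 log units; beyond the scatter). Among the compounds with values here, that is the only step in the set, and it concerns the substituent on the amine nitrogen, not the configuration of the core.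

Compound 4 `CN1C[C@@H]2C=C(c3cccnc3)C[C@@H](C2)C1` is the next candidate. It differs from compound 1 as follows: the two compounds have the same atoms and bonds and differ only in configuration as drawn: 2 of 2 stereo elements differ (all stereocentres are inverted: mirror images); a stereocentre at a saturated ring carbon is drawn R in compound 1 and S in compound 4; a stereocentre at a saturated ring carbon is drawn S in compound 1 and R in compound 4. Within the data shown here, no measured pair in the set compares two mirror images, so nothing here tells how large a step inversion of the core produces, nor in which direction. The three values only show that the amine substitution and the pyridine substituent each move this assay strongly; the configuration has not yet been tested.

Among the measured compounds shown here, with no bearing step to lean on, compound 4 is expected to give 300 nM, with a wide range from 50 nM to 2000 nM, the step from compound 1 being estimated as no change at the digits printed from compound 1 to compound 4 (within the scatter).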

Compound 4, inhibition constant: 320 nM
Beside the measured number, compound 4's estimate is 1.1-fold (0.03 log units) below it; the range from low to high includes it.
By their numbers in this assay, from the lowest: compound 2; then compound 3; then compounds 1 and 4 (each within the scatter of the next).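

In this assay, inverting both stereocentres of compound 1 gives a 1.1-fold higher number from compound 1 to compound 4 (0.03 log units; within the scatter), so with methyl on the amine nitrogen the two mirror images are not separated by this read-out. The comparison isolates configuration, because nothing else varies within the pair: the fact that compounds 1 and 4 differ only in the configuration as drawn. Set against a 320-fold lower number from compound 1 to compound 2 (2.50 log units; beyond the scatter), this shows that the amine nitrogen substituent can shift the number strongly while full inversion of the methylated core leaves it within the scatter, a finding that rests on this single mirror-image pair.

Going by these compounds, it remains open whether inversion stays equally silent with hydrogen on the amine nitrogen, as in compound 2, where the number is far lower and the mirror-image relationship could read differently. Also open, on these data alone, is how groups such as ethyl or benzyl on that nitrogen would behave in either configuration, and whether an amine or a methoxy group on the pyridine, in place of the phenoxy group of compound 3, would show any dependence on configuration.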